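Adding One Fluoro to a Soluble Piperidine

The compounds below may be only part of what the source reports. "The series", "measured", "known", "first", "only" and "open" are said of these compounds alone.

Measured in a physicochemical assay for solubility, measured as kinetic solubility; on this read-out lower numbers stand for lower solubility and higher numbers for higher solubility:
- Compound 1 `O=C(Nc1ccnnc1)c1cc(C(F)(F)F)ccc1OCc1ccccc1`: < 1000 nM, a limit
- Compound 2 `O=C(Nc1ccnnc1)c1cc(N2CCCCC2)ccc1OCc1ccccc1`: 60000 nM
- Compound 3 `O=C(Nc1cccc(F)c1)c1cc(C(F)(F)F)ccc1OCc1ccc(F)cc1`: < 1000 nM, a limit

Compound 2 alone has a true number. Everything else shown is the limit of < 1000 nM in this assay, at which 2 of the 3 values shown sit.

Compound 4 `O=C(Nc1ccnnc1)c1cc(N2CCC(F)CC2)ccc1OCc1ccccc1` alters compound 2 in one place, piperidin-1-yl to 4-fluoropiperidin-1-yl: fluoro in place of hydrogen on a saturated ring carbon.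

Within the data shown here, the only measured step, an at least 60-fold higher number from compound 1 to compound 2 (1.77 log units; beyond the scatter), was large, but it replaced trifluoromethyl with the whole piperidin-1-yl group. This new change is far smaller, so no step beyond the scatter is expected in this assay.

The expected change is a 1.3-fold lower number from compound 2 to compound 4 (0.12 log units; within the scatter). For compound 4 the estimated value is 45000 nM, with an expected range from 18000 nM to 90000 nM.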

Compound 4, solubility: 20000 nM
For compound 4 the middle estimate is 2.3-fold (0.35 log units) above the measured one; measured number inside the range.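

Even a one-atom change on this saturated ring carbon, three ring bonds from the ring nitrogen, registers in this assay, with a 3.0-fold lower number from compound 2 to compound 4 (0.48 log units; beyond the scatter). The piperidine bearing fluoro still stands clear of the trifluoromethyl group it replaces, with an at least 20-fold higher number from compound 1 to compound 4 (1.30 log units; beyond the scatter). Compound 1 gives < 1000 nM, which is a limit and not a number: the limit of < 1000 nM in this assay, at which 2 of the 4 values shown sit.

As far as these compounds go, whether the same shift belongs to fluoro alone remains open, since a hydroxyl or a methyl on this carbon could give a different result. From the compounds shown here alone, a second fluoro on the same carbon is an equally open case.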